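Swapping Cyclohexyl for tert-Butyl: Expected Tolerance in Liver Cells

The source may report more compounds than this note shows. Statements on the series, on what has been measured and on what is new or still open speak of the compounds shown alone.

Compound 1 `CN1CCN(CCNCc2cn(-c3ccc(F)cc3F)nc2C2CCCCC2)CC1` gives > 20000 nM in an ADME assay on Huh-7 cells (Homo sapiens) for cytotoxicity; a higher number here means that more compound is tolerated, a lower number that less compound is tolerated.
Compound 2 `Cc1ccccc1-c1nn(-c2ccc(F)cc2F)cc1CNC1CCN(S(C)(=O)=O)CC1` gives > 20000 nM.
Compound 3 `CN1CCN(CCNCc2cn(-c3ccc(C(F)(F)F)cc3)nc2-c2ccc(C(F)(F)F)cc2)CC1` gives 1500 nM.

For compound 1 that value is a limit of the assay, not a number. Compound 2 reaches the same limit. Compound 3 alone gives a number. Compound 1 thus stands at the limit of > 20000 nM in this assay, at which 2 of the 3 values shown sit. Compound 4 `CN1CCN(CCNCc2cn(-c3ccc(F)cc3F)nc2C(C)(C)C)CC1` differs from compound 1 in one place: tert-butyl in place of cyclohexyl on an aromatic carbon. Among the measured compounds shown here, no measured pair shows a change of this kind, so nothing sizes the step directly. A group of fewer heavy atoms replaces a larger one, and compound 1 already sits at the ceiling of this assay, so compound 4 is expected to stay there, the step that the limit leaves unreadable from compound 1 to compound 4 amounting to nothing beyond the scatter. Compound 4 is estimated at 30000 nM, within 10000 nM to 100000 nM.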

Compound 4, half-maximal cytotoxic concentration: > 20000 nM
Compound 4 ended at the assay's limit; the forecaster's own chance of this, stated with the estimate: 75%; the middle value lies beyond the limit too.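

Compound 1 and compound 4 both give a limit rather than a number in this assay, so the step between them cannot be read. As far as these compounds go, how much compound either one tolerates beyond that limit stays open.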